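Cytotoxicity of an indolinone series on prostate epithelial cells

A few compounds are considered here, and "the series" means these few. Any claim that something is new, unique, unknown or untested is made for them only; others in the source may bear on it.

Measured compounds:
Compound 1, `Cn1cc(/C=C2/C(=O)Nc3ccccc32)c2cc(Nc3nccc(-c4ccccc4)n3)ccc21`: 95600 nM
Compound 2, `Cc1ccc(-c2ccnc(Nc3ccc4c(c3)c(/C=C3/C(=O)Nc5ccccc53)cn4C)n2)cc1`: "not determined" (no result reported)
Compound 3, `Cn1cc(/C=C2/C(=O)Nc3ccccc32)c2cc(Nc3nccc(-c4ccc(C(F)(F)F)cc4)n3)ccc21`: "not determined" (no result reported)

Within the data shown here, compound 1 is the only member of the set with a number in an ADME assay on RWPE-1 cells (Homo sapiens) for cytotoxicity, read by MTT assay, with a stated time of 48 h (a higher number here means a weaker inhibitor, a lower number a stronger inhibitor), where compound 1 gives 95600 nM. Compound 2 has no result there, and compound 3 likewise has no result in this assay, so compound 3 stands without a value and without a step to any other compound. Compound 4, `Cn1cc(/C=C2/C(=O)Nc3ccccc32)c2cc(Nc3nccc(-c4cccs4)n3)ccc21`, is the next member to be tested. It differs from compound 3 in one place: thiophen-2-yl in place of 4-(trifluoromethyl)phenyl on an aromatic carbon. Among the measured compounds shown here, no pair of measured compounds in this assay differs in just one place, so the size of such a step is not known from these data. Given that the one measured compound, compound 1, shows only weak cytotoxicity, the expectation for compound 4 is a value of a similar order, with any change lying within the scatter rather than beyond it. Compound 4 is thus estimated to give 85000 nM in this assay, with a range from 35000 nM to 200000 nM.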

Compound 4, half-maximal inhibitory concentration: 64900 nM
For compound 4 the middle estimate is 1.3-fold (0.12 log units) above the measured one; the range from low to high includes it.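

In this assay, among these compounds, the swap of phenyl for thiophen-2-yl, on an aromatic carbon of a six-membered aromatic ring with 2 nitrogen, gives a 1.5-fold lower number from compound 1 to compound 4 (0.17 log units; within the scatter) and is the only one-place comparison here with a number at both ends. It shows that this position accepts a five-membered ring holding sulfur in place of a six-membered ring of carbon only, with no difference that stands clear of repeat-to-repeat variation in this cell assay. Nothing independent of these values bears on this result, so it offers no explanation for it.

Compound 2 and compound 3 have no value, so steps involving them, including the one to the 4-(trifluoromethyl)phenyl group of compound 3, cannot be read. Going by these compounds, how a piperidine ring or a carboxylic acid in this place would read remains open.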